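Trading the Amide Nitrogen for a Hydrogen

This account rests on a few compounds, and the source may have more. Where it says the series, first, only, none or still open, it means among the compounds named here.

Compound 2 `COc1cccc(-c2cc(C(N)=O)cc3cc(C(O)(c4ccc(C#N)cc4)c4cncn4C)oc23)c1` carries a carbamoyl group on its shared core. Within the data shown here, in a functional assay on QG-56 cells (Homo sapiens) for antiproliferative activity (a lower number here means a stronger inhibitor, a higher number a weaker inhibitor), compound 2 gives 8.2 nM, the lowest of the two numbers measured so far. Among the measured compounds shown here, its only measured neighbour is compound 1 `COc1cccc(-c2cc(CO)cc3cc(C(O)(c4ccc(C#N)cc4)c4cncn4C)oc23)c1`, which bears a hydroxymethyl in the same place; in this assay compound 1 gives 16.8 nM. The step of a 2.0-fold lower number from compound 1 to compound 2 (0.31 log units; beyond the scatter) is the one change recorded among these compounds.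

Compound 3 `COc1cccc(-c2cc(C=O)cc3cc(C(O)(c4ccc(C#N)cc4)c4cncn4C)oc23)c1` has not yet been measured. It differs from compound 2 in this way: hydrogen in place of amino on a carbonyl carbon. For the measured compounds named here, no measured step removes an amino group from a carbonyl carbon, so the single recorded step offers only indirect guidance: it shows that this position tolerates an exchange of a small group with a modest shift in the number. Because a 2.0-fold lower number from compound 1 to compound 2 (0.31 log units; beyond the scatter) was modest, the step of a 1.8-fold higher number from compound 2 to compound 3 (0.26 log units; within the scatter) is expected to be small as well, most likely a slight rise in the number. Compound 3 is therefore estimated at 15 nM, within a range from 5 nM to 45 nM.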

Compound 3, half-maximal inhibitory concentration: 15.2 nM
The estimate for compound 3 lay 1.0-fold (0.01 log units) below the measured number; measured number inside the range.
By their numbers in this assay, from the lowest: compounds 2, 3 and 1 (each within the scatter of the next, the first and the last beyond it).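

In this assay, removing the amino group from the carbonyl carbon gives a 1.9-fold higher number from compound 2 to compound 3 (0.27 log units; within the scatter) and so leaves the formyl group of compound 3 not distinguishable from the carbamoyl group of compound 2. Replacing hydroxymethyl with formyl gives a 1.1-fold lower number from compound 1 to compound 3 (0.04 log units; within the scatter) and so leaves compound 3 not distinguishable from compound 1 either, even though compound 1 and compound 2 were separated by more than the scatter. The formyl compound therefore fits within the scatter of both neighbours, which shows that the amino group is not required for a number close to that of compound 2, although nothing available explains why the three numbers lie so close together.

Still open, on these data alone, is whether a carboxylic acid or a methyl ester on the same aromatic carbon would keep the number within this narrow span, since both would retain the carbonyl carbon while replacing the amino group or the hydrogen. An aminomethyl group or a longer chain ending in a hydroxyl group would test how far the position tolerates changes without a carbonyl.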